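Swapping a bromo for a methyl on the thiourea aryl ring

The source may report more compounds than this note shows. Statements on the series, on what has been measured and on what is new or still open speak of the compounds shown alone.

Of the compounds shown here, three from one series have been tested for how strongly they slow the growth of a leukaemia cell line, measured in a functional assay on HL-60 cells (Homo sapiens) for antiproliferative activity, with a stated time of 24 h; a higher number here means a weaker inhibitor, a lower number a stronger inhibitor. Compound 1 `NC(=O)c1c(NC(=O)c2ccccc2Br)sc2c1CCN(C(=S)Nc1ccccc1Cl)C2` gives 14600 nM. Compound 2 `Cc1ccccc1C(=O)Nc1sc2c(c1C(N)=O)CCN(C(=S)Nc1ccccc1Cl)C2` gives 20900 nM. Compound 3 `NC(=O)c1c(NC(=O)c2ccccc2C(F)(F)F)sc2c1CCN(C(=S)Nc1ccccc1Br)C2` gives 25500 nM. The three numbers sit close together, and none of the gaps between them is large enough to rank the compounds.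

Compound 2 arises from compound 1 by a single change, (methyl in place of bromo on an aromatic carbon), and this produced a 1.4-fold higher number from compound 1 to compound 2 (0.16 log units; within the scatter). A fourth compound, compound 4 `Cc1ccccc1NC(=S)N1CCc2c(sc(NC(=O)c3ccccc3C(F)(F)F)c2C(N)=O)C1`, is not yet measured. It arises from compound 3 by methyl in place of bromo on an aromatic carbon. The place of the change is described in the same words for both pairs, so this is the same change made twice, although one bond further out it sits on a (2-bromophenyl)carbonyl in the first pair and on a (2-bromophenyl)amino in the second. The difference between the two cores, that of compound 1 and that of compound 3, is not broken down here.

Within the data shown here, with only one earlier example of this change, the expectation for compound 4 rests on the small step seen from compound 1 to compound 2, a 1.4-fold higher number from compound 1 to compound 2 (0.16 log units; within the scatter), and on the value of compound 3, 25500 nM. Compound 4 is therefore expected to show a 1.2-fold higher number from compound 3 to compound 4 (0.07 log units; within the scatter). The estimate for compound 4 in this assay is 30000 nM, with a plausible range from 15000 nM to 60000 nM.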

Compound 4, half-maximal inhibitory concentration: 25100 nM
For compound 4 the middle estimate is 1.2-fold (0.08 log units) above the measured one; measured number inside the range.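

In this assay, the second example of methyl in place of bromo gives a 1.0-fold lower number from compound 3 to compound 4 (0.01 log units; within the scatter). Set beside the first example, the two steps do not differ by more than repeated measurements would be expected to: the same change on two cores in this assay, a 1.4-fold higher number (0.16 log units; within the scatter) from compound 1 to compound 2 and a 1.0-fold lower number (0.01 log units; within the scatter) from compound 3 to compound 4, 1.5-fold (0.16 log units) apart, within the scatter of two such steps. In both pairs, then, this swap leaves the number within the scatter, which is consistent with the change carrying over between the two cores, but it does not show that the change would behave the same way on any other core: two small steps are a weak test of transfer, and the swap sits on a (2-bromophenyl)carbonyl in one pair and on a (2-bromophenyl)amino in the other.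

The swaps shown involve only bromo and methyl, so it remains open whether a group of a different kind in that place, such as an amine or a carboxylic acid, would shift the number beyond the scatter. Going by these compounds, it also remains open whether the same small steps would appear in a different cell line or over a different exposure time.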